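This account rests on a few compounds, and the source may have more. Where it says the series, first, only, none or still open, it means among the compounds named here.

Three compounds have so far been measured in a functional assay on MOLT-4 cells (Homo sapiens) for cytotoxicity, read by sulforhodamine B assay, with a stated time of 48 h, tested at 1 uM; a higher number here means a weaker effect of the compound at the concentration tested, a lower number a stronger effect:

Compound 1 `COc1ccc(-c2cc(/C=C/C(=O)c3ccc(N)cc3)[nH]n2)cc1` gives 80%
Compound 2 `COc1ccc(-c2cc(/C=C/C(=O)c3ccc(N)cc3)[nH]n2)cc1OC` gives 93%
Compound 3 `COc1cc(C(=O)/C=C/c2cc(-c3cc(OC)c(OC)c(OC)c3)n[nH]2)cc(OC)c1OC` gives 81%

Compound 2 and compound 1 differ in a single place, the change (hydrogen in place of methoxy on an aromatic carbon), and this change carried the step of a number 13 percentage points lower from compound 2 to compound 1 (beyond the scatter). Compound 3 stands close to compound 1; its numbers against compound 2 are further apart, but how the core of compound 3 differs from the core of compound 2 is not broken down here.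

Compound 4 `COc1ccc(-c2cc(/C=C/C(=O)c3cc(OC)c(OC)c(OC)c3)[nH]n2)cc1OC` is not yet measured. It differs from compound 3 by hydrogen in place of methoxy on an aromatic carbon. Within the data shown here, this is the same kind of change as the one from compound 2 to compound 1, but not the same: in compound 3 the place is also meta to a methoxy group, which the earlier place is not. The change is seen only once among the measured compounds, so the expectation rests on that one step alone. The expected step of a number 11 percentage points lower from compound 3 to compound 4 (beyond the scatter) is set beside the measured a number 13 percentage points lower from compound 2 to compound 1 (beyond the scatter) because compound 3 starts from 81%. Compound 4 is therefore expected to give 70%. The estimate for compound 4 is expected to fall between 55% and 88%.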

Compound 4, a percentage reported as activity, at one concentration (the size of the read-out at that concentration, not a potency): 69%
The estimate for compound 4 lay 1 percentage points above the measured number, within the range that was stated.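

In this assay, putting hydrogen in place of methoxy on an aromatic carbon gave a number 12 percentage points lower from compound 3 to compound 4 (beyond the scatter), and this step agrees in size with the one seen earlier on the other core: the same change on two cores in this assay, a number 13 percentage points lower (beyond the scatter) from compound 2 to compound 1 and a number 12 percentage points lower (beyond the scatter) from compound 3 to compound 4, 1 percentage points apart, within the scatter of two such steps The change therefore carried over between these two cores with much the same size, although its place in the core of compound 3 is also meta to a methoxy group. Among these compounds, this rests on only two pairs, read at a single concentration in one cell line, so it gives no rule for other cores and does not show why the number falls.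

The compounds shown leave open whether a different group at this place, such as a hydroxyl, a fluorine or a carboxylic acid, would give a step of similar size. They also leave open whether the step would hold at other concentrations.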